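The source may hold more compounds than are shown below. What is called first, only, known or untested is meant among the compounds shown, and "the series" means these compounds.

Working notes on the series: in an ADME assay on microsomes from liver (Rattus norvegicus) for metabolic stability, with a stated time of 30 min (a higher number here means that more of the compound is left, a lower number that less of the compound is left), compound 1 `COc1ccc(F)cc1C(=O)c1cc(-c2ccc(Cl)cc2)n(-c2ccc(S(N)(=O)=O)cc2)c1C` gives 45%, the lower of the two numbers measured so far. Among the measured compounds shown here, the only other measured member, compound 2 `Cc1c(C(=O)C2CC2)cc(-c2ccc(Cl)cc2)n1-c1ccc(S(N)(=O)=O)cc1`, gives 92%. Still unmeasured is compound 3 `Cc1c(C(=O)CC(C)C)cc(-c2ccc(Cl)cc2)n1-c1ccc(S(N)(=O)=O)cc1`, which has isobutyl in place of 5-fluoro-2-methoxyphenyl on a carbonyl carbon. For the measured compounds named here, one measured step bears on this change: a number 47 percentage points higher from compound 1 to compound 2 (beyond the scatter), with cyclopropyl in place of the same 5-fluoro-2-methoxyphenyl on the carbonyl carbon. That step is large and beyond the scatter. Going by the values given here, it is also the only evidence available, and no measured compound yet carries an open chain at this place, so the transfer to isobutyl is uncertain. On the basis of a number 47 percentage points higher from compound 1 to compound 2 (beyond the scatter), a rise of clear size is still expected in this assay, though probably a somewhat smaller one. The expected step is a number 33 percentage points higher from compound 1 to compound 3 (beyond the scatter). For compound 3 the estimated value is 78%, with an expected range from 58% to 95%.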

Compound 3, percent of the compound remaining: 44%
For compound 3 the middle estimate is 34 percentage points above the measured one, and the stated range ends above it.
By their numbers in this assay, from the lowest: compounds 3 and 1 (each within the scatter of the next); then compound 2.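

In this assay, replacing 5-fluoro-2-methoxyphenyl on the carbonyl carbon with isobutyl gives a number 1 percentage points lower from compound 1 to compound 3 (within the scatter), so leaving out the aromatic ring does not by itself bring the large gain seen with cyclopropyl. Among the compounds shown here, the isobutyl and cyclopropyl groups, both without an aromatic ring, are clearly separated at this place, with a number 48 percentage points lower from compound 2 to compound 3 (beyond the scatter), which makes the high number so far specific to cyclopropyl rather than shared by both non-aromatic groups. No measurement shown here gives a reason for this difference between the two groups.

From the compounds shown here alone, it remains open whether the high number depends on the cyclopropyl ring as such or would also appear with another small ring such as cyclobutyl, or with a shorter chain such as ethyl. Also open, going by these compounds, is whether an open chain carrying a polar group, such as an amine or a carboxylic acid, would stay with compound 1 and compound 3 in this assay or move toward compound 2.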